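Fluoro to Cyano on the Biaryl Ring: Expected Tolerance

This account rests on a few compounds, and the source may have more. Where it says the series, first, only, none or still open, it means among the compounds named here.

Compound 1 `Cc1cc(-c2ccc(F)cc2)cc(C)c1Oc1cc(N)nc(Nc2ccc(C#N)cc2)n1`: in a toxicity assay on MT4 cells (Homo sapiens) for cytotoxicity, read by MTT assay (a higher number here means that more compound is tolerated, a lower number that less compound is tolerated), compound 1 gives 23100 nM.
Compound 2 `Cc1cc(-c2ccc(C#N)cc2)cc(C)c1Oc1cc(N)nc(Nc2ccc(C#N)cc2)n1`: in this assay compound 2 gives 18100 nM.
Compound 3 `Cc1cc(-c2ccc(C#N)c(F)c2)cc(C)c1Oc1cc(N)nc(Nc2ccc(C#N)cc2)n1`: in this assay compound 3 gives 5000 nM.

The core of compound 3 differs from that of compound 1 by 4-cyano-3-fluorophenyl in place of 4-fluorophenyl on an aromatic carbon, and this change gave a 4.6-fold lower number from compound 1 to compound 3 (0.66 log units; beyond the scatter). Compound 2 and compound 3 also stand apart by a single fluoro, with a 3.6-fold lower number from compound 2 to compound 3 (0.56 log units; beyond the scatter).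

The change from compound 1 to compound 2 is cyano in place of fluoro on an aromatic carbon. It gave a 1.3-fold lower number from compound 1 to compound 2 (0.11 log units; within the scatter).

Compound 4 `Cc1cc(-c2ccc(C#N)c(C#N)c2)cc(C)c1Oc1cc(N)nc(Nc2ccc(C#N)cc2)n1` has not yet been measured. It arises from compound 3 by cyano in place of fluoro on an aromatic carbon. This is the same kind of change as that from compound 1 to compound 2, but the surroundings differ: in compound 2 the entering cyano sits para to a large group, while in compound 4 it sits ortho to a cyano group and meta to a large group.

In this assay the expected step is a 1.3-fold lower number from compound 3 to compound 4 (0.10 log units; within the scatter). That expectation rests on the earlier pair, where the same kind of change gave a 1.3-fold lower number from compound 1 to compound 2 (0.11 log units; within the scatter), and on compound 3 having given 5000 nM. Compound 4 is thus estimated at 4000 nM, most likely between 1500 nM and 10000 nM.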

Compound 4, half-maximal cytotoxic concentration: 17600 nM
Beside the measured number, compound 4's estimate is 4.4-fold (0.64 log units) below it; the measured number lies above the stated range.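

In this assay, putting cyano in place of fluoro gave a 3.5-fold higher number from compound 3 to compound 4 (0.55 log units; beyond the scatter), so the near-absence of change seen on the core of compound 1 did not carry over to the core of compound 3. Set side by side, the two cases differ: the same change on two cores in this assay, a 1.3-fold lower number (0.11 log units; within the scatter) from compound 1 to compound 2 and a 3.5-fold higher number (0.55 log units; beyond the scatter) from compound 3 to compound 4, 4.5-fold (0.65 log units) apart, beyond the scatter of two such steps. Compound 4 lies within the scatter of the other two compounds, with a 1.0-fold lower number from compound 2 to compound 4 (0.01 log units; within the scatter) and a 1.3-fold lower number from compound 1 to compound 4 (0.12 log units; within the scatter), but two pairs in one assay cannot say why the same change behaved differently or how it would behave on a further core.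

The compounds shown leave open whether a chloro or a methoxy group in place of that fluoro would give a number like that of compound 3 at 5000 nM or one like that of compound 4 at 17600 nM. As far as these compounds go, how an amine or a carboxylic acid would fare at that place also remains open.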